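Extending a Methyl to Propyl on Two Different Cores

The source may report more compounds than this note shows. Statements on the series, on what has been measured and on what is new or still open speak of the compounds shown alone.

Compound 1 `CN(C)/N=N/c1n[nH]cc1C(N)=O` was tested in a functional assay on L1210 cells (Mus musculus) for antiproliferative activity (a higher number here means a more potent compound, by a factor of ten per unit of this negative logarithm, a lower number a less potent compound), where compound 1 gives 3.49. Compound 2 `CCCN(C)/N=N/c1n[nH]cc1C(N)=O` differs from it by ethyl in place of hydrogen on a saturated chain carbon bound to an amine nitrogen; in this assay compound 2 gives 3.7, which is a number 0.21 log units higher from compound 1 to compound 2 (within the scatter). Compound 3 `CN(C)/N=N/c1ccccc1C(N)=O` rests on another core, and the difference between the two cores is not broken down here. In this assay compound 3 gives 3.31. Within the data shown here, compound 4 `CCCN(C)/N=N/c1ccccc1C(N)=O` has not been measured yet; it differs from compound 3 by ethyl in place of hydrogen on a saturated chain carbon bound to an amine nitrogen, the same change at the same place as the one leading from compound 1 to compound 2. Because that earlier change gave a number 0.21 log units higher from compound 1 to compound 2 (within the scatter), a step of about a number 0.19 log units higher from compound 3 to compound 4 (within the scatter) is expected here as well. Compound 4 is therefore estimated at 3.5, likely between 3.1 and 3.9.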

Compound 4, logarithm of the reciprocal of the active concentration, log(1/C): 3.26
Compound 4: the middle estimate sits 0.24 log units above what was measured; measured number inside the range.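

In this assay, going from methyl to propyl on the core of compound 3 gives a number 0.05 log units lower from compound 3 to compound 4 (within the scatter). Set beside the same change on the core of compound 1, the two results cannot be told apart: the same change on two cores in this assay, a number 0.21 log units higher (within the scatter) from compound 1 to compound 2 and a number 0.05 log units lower (within the scatter) from compound 3 to compound 4, 0.26 log units apart, within the scatter of two such steps. Among these compounds, this shows that the change carries from one core to the other without any difference that stands clear of the usual scatter, but it does not prove that the two cores respond alike, as both steps are small and each core offers only a single pair.

As far as these compounds go, whether a longer chain such as hexyl, or a chain ending in an amine, would set the two cores apart remains open. Also open, from the compounds shown here alone, is whether any other group at this place would move the number beyond the scatter on either core.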